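Nitrophenyl to Formylphenyl on a Weakly Active Aryl Ether Series

The source may hold more compounds than are shown below. What is called first, only, known or untested is meant among the compounds shown, and "the series" means these compounds.

Measured compounds:
- Compound 1 `c1ccc(COc2ccc(OCCOCCNc3ccncc3)cc2)cc1`: 20600 nM
- Compound 2 `O=[N+]([O-])c1cccc(COc2ccc(OCCOCCNC3CCCC3)cc2)c1`: 15400 nM
- Compound 3 `c1cc2c(cc1OCCOCCNC1CCCC1)CCCC2`: 31900 nM

Of the compounds shown here, three have been tested in a functional assay on SK-OV-3 cells (Homo sapiens) for inhibition, read by CCK-8 assay, with a stated time of 70 h; a lower number here means a stronger inhibitor, a higher number a weaker inhibitor. All three sit in the weak range. Compound 2 gives the lowest of the three numbers, with 15400 nM. Compound 1 lies nearest to it, and the gap between compound 2 and compound 1 stays within the scatter. Compound 3 lies furthest, and the gap between compound 2 and compound 3 goes beyond the scatter.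

Compound 4 `O=Cc1ccc(COc2ccc(OCCOCCNC3CCCC3)cc2)cc1` has not yet been tested in this assay. It differs from compound 2 in one place: 4-formylphenyl in place of 3-nitrophenyl on a saturated chain carbon bound to an oxygen on an aromatic ring.

Among the measured compounds shown here, no step between two measured compounds has been determined, so no direct guide exists for the size of the change. Given that compound 1, which carries a plain benzyl group, gives 20600 nM and sits within the scatter of compound 2, the expectation is that swapping one substituted phenyl for another leaves the number roughly where it is, with a step of a 1.1-fold higher number from compound 2 to compound 4 (0.04 log units; within the scatter) that is expected to be none beyond the scatter. The estimate for compound 4 is 17000 nM, with a range from 7000 nM to 40000 nM.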

Compound 4, half-maximal inhibitory concentration: 45000 nM
Beside the measured number, compound 4's estimate is 2.6-fold (0.42 log units) below it, outside the stated range (above it).
By their numbers in this assay, from the lowest: compounds 2, 1, 3 and 4 (each within the scatter of the next, the first and the last beyond it).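

In this assay, among the compounds shown here, the exchange of 3-nitrophenyl for 4-formylphenyl on a saturated chain carbon bound to an oxygen on an aromatic ring gives a 2.9-fold higher number from compound 2 to compound 4 (0.47 log units; beyond the scatter) and is the first step read between two compounds differing in one place. It shows that this position is not indifferent to which substituted phenyl it carries, and that this exchange makes the inhibitor weaker, although the step is modest. Nothing at hand accounts for the step.

The compounds shown leave open whether the step follows the nitro-to-formyl exchange or the move from a 3-substituted to a 4-substituted phenyl, as the two change together. They also leave open how this assay would respond to a nitrile or a carboxylic acid in place of the formyl group.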